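Replacing 2-cyano-4-fluorophenyl with pyridin-2-yl: working notes

The source may report more compounds than this note shows. Statements on the series, on what has been measured and on what is new or still open speak of the compounds shown alone.

Measured in an in vivo ADME assay on the whole organism (Rattus norvegicus) for pharmacokinetics; on this read-out lower numbers stand for lower oral bioavailability and higher numbers for higher oral bioavailability:
- compound 1 `CC1=C(C(=O)NCCCN2CCC(c3ccccc3C#N)CC2)[C@@H](c2ccc(F)c(F)c2)NC(=O)N1`: 0%
- compound 2 `CC1=C(C(=O)NCCCN2CCC(c3ccc(F)cc3)CC2)[C@@H](c2ccc(F)c(F)c2)NC(=O)N1`: < 6%
- compound 3 `CC1=C(C(=O)NCCCN2CCC(c3ccc(F)cc3C#N)CC2)[C@@H](c2ccc(F)c(F)c2)NC(=O)N1`: 0%

The entry for compound 2, < 6%, is a limit of the assay and not a number.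

Compound 3 stands at 0%, level with compound 1 at the digits given. The next structure, compound 4 `CC1=C(C(=O)NCCCN2CCC(c3ccccn3)CC2)[C@@H](c2ccc(F)c(F)c2)NC(=O)N1`, carries pyridin-2-yl in place of 2-cyano-4-fluorophenyl on a saturated ring carbon. The place is a six-membered non-aromatic ring with 1 nitrogen, three ring bonds from the ring nitrogen.

Among the compounds with values here, only one measured step has a readable size: no change at the digits printed from compound 1 to compound 3 (within the scatter). It stays within the scatter. Two others touch the same substituent, a step that the limit leaves unreadable from compound 1 to compound 2 and a step that the limit leaves unreadable from compound 2 to compound 3, but neither gives a size. Within the data shown here, no measured step brings in pyridin-2-yl, so the expectation rests on a thin base.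

Among the measured compounds shown here, with compound 3 at 0% and no change at the digits printed from compound 1 to compound 3 (within the scatter) as the only readable step, no expected move in this assay goes beyond the scatter, and any small move would be upward. The expected step is a number 3 percentage points higher from compound 3 to compound 4 (within the scatter). For compound 4 the estimated value is 3%. The expected range for compound 4 runs from 0% to 12%.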

Compound 4, oral bioavailability: 0%
For compound 4 the middle estimate is 3 percentage points above the measured one; low and high end bracket the measured number.
By their numbers in this assay, from the lowest: compounds 1, 3 and 4 (each within the scatter of the next).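

In this assay, the readable steps at this place are no change at the digits printed from compound 3 to compound 4 (within the scatter) and no change at the digits printed from compound 1 to compound 4 (within the scatter). Within the data shown here, until now, the only readable step was the addition of fluoro to the aromatic ring; here the whole group is exchanged, with 2-cyano-4-fluorophenyl of 9 heavy atoms giving way to pyridin-2-yl of 6 heavy atoms, a ring with 1 hetero atom and no nitrile, and the read-out stays within the scatter. Compound 2 carries a limit, < 6%, and the steps that involve it cannot be read: the limit of < 6% in this assay, at which 1 of the 4 values shown sits.

With compounds 1, 3 and 4 level, the compounds shown do not tell whether any group on this saturated ring carbon can bring a readable change in oral bioavailability, or whether the answer lies elsewhere in the shared core. An amine or a carboxylic acid on this carbon would bear on that question, and the compounds shown hold no change outside this place.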